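Replacing the aryl ether of compound 3 with a benzyl group

This account rests on a few compounds, and the source may have more. Where it says the series, first, only, none or still open, it means among the compounds named here.

Compound 3 `CC(C)(Oc1ccccc1O)C1OCC(C/C=C\CCC(=O)O)C(c2cccnc2)O1` sits at the top end of the numbers shown in an assay for inhibition of prostacyclin synthase (Homo sapiens), using microsomes; on this read-out lower numbers stand for stronger inhibition and higher numbers for weaker inhibition. In this assay compound 3 gives > 100000 nM, which is a limit of the assay and not a number (the limit of > 100000 nM in this assay, at which 1 of the 3 values shown sits). Compound 2 `COc1ccccc1OC(C)(C)C1OCC(C/C=C\CCC(=O)O)C(c2cccnc2)O1` gives 51000 nM in this assay. Compound 1 `CC(C)(Oc1ccccc1F)C1OCC(C/C=C\CCC(=O)O)C(c2cccnc2)O1` gives < 1000 nM in this assay, and that too is a limit of the assay (the limit of < 1000 nM in this assay, at which 1 of the 3 values shown sits). The measured steps that frame compound 3 are an at least 100-fold higher number from compound 1 to compound 3 (2.00 log units; beyond the scatter) and an at least 1.9-fold higher number from compound 2 to compound 3 (0.29 log units; that floor lies within the scatter); the step of an at least 51-fold higher number from compound 1 to compound 2 (1.70 log units; beyond the scatter) shows the same direction. The change to compound 4 `CC(C)(Cc1ccc(F)cc1)C1OCC(C/C=C\CCC(=O)O)C(c2cccnc2)O1` is 4-fluorobenzyl in place of 2-hydroxyphenoxy on a saturated chain carbon bound to two saturated chain carbons and a saturated ring carbon. It takes out the hydroxy that went with the large step of an at least 100-fold higher number from compound 1 to compound 3 (2.00 log units; beyond the scatter) and brings a fluoro on the aromatic ring back, as in compound 1, though now on a benzyl group joined through carbon rather than through oxygen. The step of an at least 100-fold higher number from compound 1 to compound 3 (2.00 log units; beyond the scatter) therefore bears most on it, and the expected step is a large one downward, an at least 33-fold lower number from compound 3 to compound 4 (1.52 log units; beyond the scatter), though the link through carbon leaves the size uncertain. The estimate for compound 4 in this assay is 3000 nM, with a range from 300 nM to 30000 nM.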

Compound 4, half-maximal inhibitory concentration: 2000 nM
Compound 4: middle estimate off by 1.5-fold (0.18 log units), on the high side, within the range that was stated.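

In this assay, the place on a saturated chain carbon bound to two saturated chain carbons and a saturated ring carbon accepts a group joined through carbon, and compound 4 gives 2000 nM without any phenoxy oxygen. The 4-fluorobenzyl group clearly improves on the two phenoxy groups with an oxygen substituent, with an at least 50-fold lower number from compound 3 to compound 4 (1.69 log units; beyond the scatter) and a 26-fold lower number from compound 2 to compound 4 (1.41 log units; beyond the scatter), whereas the comparison with the 2-fluorophenoxy group gives an at least 2.0-fold higher number from compound 1 to compound 4 (0.30 log units; that floor lies within the scatter), so no order between those two groups can be stated. The value of compound 1 is a limit and not a number: the limit of < 1000 nM in this assay, at which 1 of the 4 values shown sits.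

These steps change the link to the ring and the substituent together, so they do not separate the contribution of the carbon link from that of the fluoro. A plain benzyl group, or a benzyl group carrying a methoxy or an amine in place of the fluoro, would be needed to tell whether the sharp loss seen with oxygen substituents on the phenoxy ring carries over to the benzyl series.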